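Furan-2-yl for pyridin-2-yl: what compound 4 should show

The source may report more compounds than this note shows. Statements on the series, on what has been measured and on what is new or still open speak of the compounds shown alone.

In a functional assay on HCT-15 cells (Homo sapiens) for cytotoxicity, read by CCK-8 assay and cell counting, with a stated time of 2 days (on this read-out lower numbers stand for stronger inhibition and higher numbers for weaker inhibition), three compounds have been measured:
compound 1 `Oc1cccc(-c2cc(-c3ccc(Cl)cc3)nc(-c3cccs3)c2)c1` gives 9280 nM;
compound 2 `Oc1cccc(-c2cc(-c3cccc(Cl)c3)nc(-c3ccco3)c2)c1` gives 2460 nM;
compound 3 `Oc1cccc(-c2cc(-c3ccc(Cl)cc3)nc(-c3ccccn3)c2)c1` gives 13500 nM.

Compound 3 has the highest number of the three. For the measured compounds named here, its nearest neighbour is compound 1, and the only single-change step among the measured compounds, a 1.5-fold higher number from compound 1 to compound 3 (0.16 log units; within the scatter), lies within the scatter. Going by the values given here, compound 2, which carries furan-2-yl and a 3-chlorophenyl group, stands well below compound 3, but the two differ in two places, so no single step can be drawn between them.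

Compound 4 `Oc1cccc(-c2cc(-c3ccc(Cl)cc3)nc(-c3ccco3)c2)c1` differs from compound 3 in one place: furan-2-yl in place of pyridin-2-yl on an aromatic carbon. Among the compounds with values here, the one measured step that bears on this position, a 1.5-fold higher number from compound 1 to compound 3 (0.16 log units; within the scatter), is small, which suggests that the group at this position moves the number little. Within the data shown here, the value of compound 2, the only compound with furan-2-yl, points toward a lower number, but its second difference leaves this uncertain.

Compound 4 is therefore expected to give a somewhat lower number than compound 3, with a 2.7-fold lower number from compound 3 to compound 4 (0.43 log units; beyond the scatter) as the estimated step. The estimate for compound 4 in this assay is 5000 nM, expected between 1800 nM and 14000 nM.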

Compound 4, half-maximal inhibitory concentration: 10200 nM
Beside the measured number, compound 4's estimate is 2.0-fold (0.31 log units) below it, and the stated range covers the measured number.
By their numbers in this assay, from the lowest: compound 2; then compounds 1, 4 and 3 (each within the scatter of the next).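

In this assay, the three rings on the aromatic carbon next to the ring nitrogen could not be told apart with the 4-chlorophenyl group held in place: the step to furan-2-yl from pyridin-2-yl is a 1.3-fold lower number from compound 3 to compound 4 (0.12 log units; within the scatter) and the step to furan-2-yl from thiophen-2-yl is a 1.1-fold higher number from compound 1 to compound 4 (0.04 log units; within the scatter), both within the scatter. Compound 2 therefore owes its separation from compound 4 to no change of this ring, since the two share furan-2-yl and differ only in the chlorophenyl group, which gives a 4.1-fold higher number from compound 2 to compound 4 (0.62 log units; beyond the scatter) and lies beyond the scatter; this single pair shows that the position of the chlorine on that phenyl group matters more here than the swaps among these three rings. No other measurement accompanies these numbers, so nothing here explains why they fall as they do.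

From the compounds shown here alone, whether 3-chlorophenyl gives the same shift when paired with thiophen-2-yl or pyridin-2-yl remains open, as the comparison rests on furan-2-yl alone. Also open, going by these compounds, is whether the flat response at this position extends beyond aromatic rings to a group such as a dimethylamino group, a carboxylic acid or a longer alkyl chain.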